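The source may report more compounds than this note shows. Statements on the series, on what has been measured and on what is new or still open speak of the compounds shown alone.

Measured in an in vitro ADME assay on microsomes from liver (Homo sapiens) for metabolic stability, tested at 1 uM; a higher number here means that the compound lasts longer, a lower number that the compound disappears faster:
- Compound 1 `CS(=O)(=O)Nc1ccc2c(c1)S(=O)(=O)N=C(C1=C(O)[C@@H]3[C@H]4CC[C@H](C4)[C@@H]3N(Cc3ccccc3)C1=O)N2`: > 1 h (limit)
- Compound 2 `CS(=O)(=O)Nc1ccc2c(c1)S(=O)(=O)N=C(C1=C(O)[C@@H]3[C@@H]4CC[C@@H](C4)[C@@H]3N(Cc3ccccc3)C1=O)N2`: > 1 h (limit)

Compound 2 gives > 1 h, which is a limit of the assay and not a number. Within the data shown here, the series so far offers (the limit of > 1 h in this assay, at which 2 of the 2 values shown sit). Among the measured compounds shown here, the only measured step is a step that the two limits leave unreadable from compound 1 to compound 2. It concerns (the fact that compounds 1 and 2 differ only in the configuration as drawn), so it says nothing about the benzyl group.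

Compound 3 `COc1cccc(CN2C(=O)C(C3=NS(=O)(=O)c4cc(NS(C)(=O)=O)ccc4N3)=C(O)[C@@H]3[C@@H]4CC[C@@H](C4)[C@@H]32)c1` carries methoxy in place of hydrogen on an aromatic carbon, which takes benzyl to 3-methoxybenzyl. For the measured compounds named here, no measured step touches this part of the structure, and no direction can be read from the data. The expected step is a step that the limit leaves unreadable from compound 2 to compound 3, with nothing beyond the scatter anticipated. In this assay the result may well be a limit again. The estimate for compound 3 is 1.2 h, with an expected range from 0.5 h to 3 h.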

Compound 3, half-life: > 1 h
Compound 3 gave a limit, no number; the forecaster's own chance of this, stated with the estimate: 60%; the middle value is on the limit's open side.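

Compound 3 also stands at a limit of the assay and not at a number, so no new step can be read between compound 2 and compound 3. The compounds shown leave open whether benzyl and 3-methoxybenzyl differ in half-life at all, since all share one limit: the limit of > 1 h in this assay, at which 3 of the 3 values shown sit.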